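Benzyloxy in place of propoxy: cytotoxicity outlook

The source may hold more compounds than are shown below. What is called first, only, known or untested is meant among the compounds shown, and "the series" means these compounds.

The series shares one core, carried by compound 1 `Nc1nc(NC2CC2)c2ncn(/C=C3/CC3(CO)CO)c2n1`, compound 2 `CCCOc1nc(N)nc2c1ncn2/C=C1/CC1(CO)CO` and compound 3 `CCCCCOc1nc(N)nc2c1ncn2/C=C1/CC1(CO)CO`. In an ADME assay on BCBL1 cells (Homo sapiens) for cytotoxicity, with a stated time of 7 days (a higher number here means that more compound is tolerated, a lower number that less compound is tolerated), compound 1 gives 71500 nM. In this assay compound 2 gives > 20000 nM, which is a limit of the assay and not a number. In this assay compound 3 gives > 20000 nM, likewise a limit of the assay. Compound 2 thus stands at the limit rather than at a read number, and only compound 1 carries a number. The steps a step that the limit leaves unreadable from compound 1 to compound 2, a step that the limit leaves unreadable from compound 1 to compound 3 and a step that the two limits leave unreadable from compound 2 to compound 3 cannot be sized, since (the limit of > 20000 nM in this assay, at which 2 of the 3 values shown sit). The next compound is compound 4 `Nc1nc(OCc2ccccc2)c2ncn(/C=C3/CC3(CO)CO)c2n1`, reached from compound 2 by phenyl in place of ethyl on a saturated chain carbon bound to an oxygen on an aromatic ring. Among the measured compounds shown here, no measured step speaks to the size of this change; the closest measured step is itself unreadable. In this assay compound 4 is therefore expected to sit near the limit, with the step that the limit leaves unreadable from compound 2 to compound 4 estimated as no more than scatter. The estimate for compound 4 is 30000 nM, with a range from 8000 nM to 100000 nM.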

Compound 4, half-maximal cytotoxic concentration: > 20000 nM
Compound 4: no number, only a limit; the forecaster's own chance of this, stated with the estimate: 60%; the middle value lies beyond the limit too.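

No new step can be read between compound 4 and compound 1, compound 2 or compound 3, since the comparison stops at: the limit of > 20000 nM in this assay, at which 3 of the 4 values shown sit. The compounds shown leave open, in this assay, whether propoxy, pentyloxy and benzyloxy differ at all in the concentration tolerated.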